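The source may report more compounds than this note shows. Statements on the series, on what has been measured and on what is new or still open speak of the compounds shown alone.

Compound 1 `Nc1nc(NCc2ccccc2)c2ncn(/C=C3/CC3(CO)CO)c2n1` in an ADME assay on Akata cells (Homo sapiens) for cytotoxicity, with a stated time of 7 days (a higher number here means that more compound is tolerated, a lower number that less compound is tolerated), gives > 24000 nM, a limit of the assay. Compound 2 `CC(C)CNc1nc(N)nc2c1ncn2/C=C1/CC1(CO)CO` in this assay gives > 24000 nM, again a limit. Compound 3 `CCCCCCSc1nc(N)nc2c1ncn2/C=C1/CC1(CO)CO` in this assay gives > 20000 nM, also a limit.

Compound 1 therefore stands only at a limit, and the two other values shown are limits too: the limit of > 24000 nM in this assay, at which 2 of the 3 values shown sit, and (the limit of > 20000 nM in this assay, at which 1 of the 3 values shown sits). Going by the values given here, none of the measured steps can be read, neither a step that the two limits leave unreadable from compound 1 to compound 2, nor a step that the two limits leave unreadable from compound 1 to compound 3, nor a step that the two limits leave unreadable from compound 2 to compound 3.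

Compound 4 `Nc1nc(SC2CCCC2)c2ncn(/C=C3/CC3(CO)CO)c2n1` differs from compound 1 by cyclopentylsulfanyl in place of benzylamino on an aromatic carbon. The three measured steps, all unreadable, give no direction for this change. Compound 4 is therefore expected to sit at the limit as well, with an estimate of 30000 nM (range 15000 nM to 80000 nM). The expected step is a step that the limit leaves unreadable from compound 1 to compound 4.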

Compound 4, half-maximal cytotoxic concentration: > 20000 nM
Compound 4: only a limit was reported; the forecaster's own chance of this, stated with the estimate: 80%; the middle value does not contradict the limit.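

Compound 4 gives > 20000 nM in this assay, again a limit, so its steps from compound 1, compound 2 and compound 3 cannot be read. Where the half-maximal cytotoxic concentration of any of these compounds lies remains open, as does whether changing the group on the aromatic carbon alters it.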